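A longer amide chain on compound 3

The source may hold more compounds than are shown below. What is called first, only, known or untested is meant among the compounds shown, and "the series" means these compounds.

Compound 1 `CCCC(=O)OCSc1ccc(OC(F)(F)F)cc1C(=O)NC(C)(C)C(N)=O`: < 56.1 uM
Compound 2 `CCCC(=O)OCSc1ccc(OC)cc1C(=O)NCCC(N)=O`: > 100 uM
Compound 3 `CCCC(=O)OCSc1ccccc1C(=O)NCCCC(N)=O`: 56.6 uM

All three compounds were tested in an ADME assay on CEM-SS cells (Homo sapiens) for cytotoxicity, read by XTT assay, with a stated time of 6 days; on this read-out lower numbers stand for higher toxicity in this test and higher numbers for lower toxicity in this test. Going by the values given here, compound 3, at 56.6 uM, has the only exact number in this small set. Compound 1 gives < 56.1 uM, which is a limit and not a number. Compound 2 gives > 100 uM, which is also a limit and not a number.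

Compound 4 `CCCC(=O)OCSc1ccccc1C(=O)NCCCCCCNC(C)=O` has not yet been measured. It differs from compound 3 in one place: 3-acetamidopropyl in place of carbamoyl on a saturated chain carbon, three bonds along the chain from an amide-type nitrogen. The new group sits on a saturated chain carbon, three bonds along the chain from an amide-type nitrogen.

Among the compounds with values here, no two measured compounds differ in just one place, so the data offer no direct guide to the size of this change. The forecast therefore rests on compound 3 at 56.6 uM, and no shift beyond the usual scatter in this assay is expected. The expected step is a 1.2-fold lower number from compound 3 to compound 4 (0.07 log units; within the scatter), leaning slightly towards the more toxic side. For compound 4 the estimated value is 48 uM, with an expected range from 20 uM to 100 uM.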

Compound 4, half-maximal toxic concentration: 8 uM
For compound 4 the middle estimate is 6.0-fold (0.78 log units) above the measured one, and the stated range ends above it.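

In this assay, the end of the amide chain turns out not to be a silent place: 3-acetamidopropyl in place of carbamoyl, on a saturated chain carbon three bonds along the chain from an amide-type nitrogen, gives a 7.1-fold lower number from compound 3 to compound 4 (0.85 log units; beyond the scatter), a move towards higher toxicity in this test. The comparison also narrows what changed, since the group that leaves and the group that enters each carry 1 hydrogen-bond donor, 1 hydrogen-bond acceptor, no ring and no net charge, while the heavy atoms go from 3 to 7, most of the gain being carbon. That is only a description of the two groups, and nothing measured here gives a reason for the lower number.

The step changes two things at once, the length of the chain and the amide at its end, and the compounds shown do not pull these apart. A plain alkyl chain of the same length, or the same chain ending in an amine or a carboxylic acid, would show whether the chain or its end group goes with the higher toxicity.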